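The source may report more compounds than this note shows. Statements on the series, on what has been measured and on what is new or still open speak of the compounds shown alone.

Of the compounds shown here, three that share one core have been measured in a functional assay on MCF7 cells (Homo sapiens) for antiproliferative activity, read by sulforhodamine B assay, with a stated time of 48 h; on this read-out lower numbers stand for stronger inhibition and higher numbers for weaker inhibition. Compound 3 `Cc1ccc(NS(=O)(=O)c2ccc(N3CCNC3=O)cc2)c(C)c1` gives 230 nM in this assay, the lowest of the two plain numbers shown. Compound 2 `COc1ccccc1NS(=O)(=O)c1ccc(N2CCNC2=O)cc1` gives 770 nM, and the step of a 3.3-fold lower number from compound 2 to compound 3 (0.52 log units; beyond the scatter) lies beyond the scatter. For compound 1 `COc1ccc(NS(=O)(=O)c2ccc(N3CCNC3=O)cc2)cc1` the assay reports only a limit, > 1000 nM, rather than a number (the limit of > 1000 nM in this assay, at which 1 of the 3 values shown sits). Compound 4 `O=C1NCCN1c1ccc(S(=O)(=O)Nc2ccc(Cl)cc2)cc1` has not yet been measured; it differs from compound 3 in one place: 4-chlorophenyl in place of 2,4-dimethylphenyl on a sulfonamide nitrogen. Going by the values given here, two measured steps bear on this change, and both end at the 2,4-dimethylphenyl of compound 3: an at least 4.3-fold lower number from compound 1 to compound 3 (0.63 log units; beyond the scatter) and a 3.3-fold lower number from compound 2 to compound 3 (0.52 log units; beyond the scatter). Because both an at least 4.3-fold lower number from compound 1 to compound 3 (0.63 log units; beyond the scatter) and a 3.3-fold lower number from compound 2 to compound 3 (0.52 log units; beyond the scatter) run towards lower numbers on arriving at 2,4-dimethylphenyl, leaving it is expected to move the number back upward, although 4-chlorophenyl is not a methoxyphenyl and these data do not show how far. The step of a 2.2-fold higher number from compound 3 to compound 4 (0.34 log units; beyond the scatter) is therefore expected to be modest and towards a higher number. Compound 4 is expected to give 500 nM in this assay, within 200 nM to 1500 nM.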

Compound 4, half-maximal inhibitory concentration: 170 nM
Beside the measured number, compound 4's estimate is 2.9-fold (0.47 log units) above it; the measured number lies below the stated range.
By their numbers in this assay, from the lowest: compounds 4 and 3 (each within the scatter of the next); then compound 2. At a limit, above all of these: compound 1.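

In this assay, 4-chlorophenyl and 2,4-dimethylphenyl on a sulfonamide nitrogen cannot be told apart, with a 1.4-fold lower number from compound 3 to compound 4 (0.13 log units; within the scatter), so the low end of this small set is not held by 2,4-dimethylphenyl alone. The chlorinated ring also stands clearly apart from 2-methoxyphenyl, with a 4.5-fold lower number from compound 2 to compound 4 (0.66 log units; beyond the scatter). The comparison with 4-methoxyphenyl, chloro in place of methoxy on an aromatic carbon, gives only a floor, an at least 5.8-fold lower number from compound 1 to compound 4 (0.76 log units; beyond the scatter), since the starting value is a limit and not a number: the limit of > 1000 nM in this assay, at which 1 of the 4 values shown sits. Open, on these data alone, is how other groups on this nitrogen would read, such as a 4-aminophenyl, a 4-carboxyphenyl or a plain hexyl chain in place of the ring. The compounds shown also give no reason why the two methoxyphenyl groups stand at higher numbers than 4-chlorophenyl.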